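Second phenyl on the chain carbon of compound 2

The source may hold more compounds than are shown below. What is called first, only, known or untested is meant among the compounds shown, and "the series" means these compounds.

Compound 2 `CO/N=c1\[nH]cnc2c1[n+](C/C=C(\C)CC/C=C(\C)CC/C=C(\C)CCC=C(C)C)cn2Cc1ccccc1` gives the lowest of the two numbers measured in a functional assay on CEM/s cells (Homo sapiens) for cytotoxicity (on this read-out lower numbers stand for stronger inhibition and higher numbers for weaker inhibition), namely 2240 nM. Compound 1 `CO/N=c1\[nH]cnc2c1[n+](C/C=C(\C)CC/C=C(\C)CC/C=C(\C)CCC=C(C)C)cn2CCC#N` gives 5360 nM in this assay. For the measured compounds named here, the only step measured, a 2.4-fold lower number from compound 1 to compound 2 (0.38 log units; beyond the scatter), put phenyl in place of cyanomethyl on a saturated chain carbon bound to an aromatic nitrogen. Compound 3 `CO/N=c1\[nH]cnc2c1[n+](C/C=C(\C)CC/C=C(\C)CC/C=C(\C)CCC=C(C)C)cn2C(c1ccccc1)c1ccccc1` carries phenyl in place of hydrogen on a saturated chain carbon bound to an aromatic carbon and an aromatic nitrogen. That single step was modest and concerned the same carbon, so a second phenyl there is expected to bring a small step, a 1.4-fold lower number from compound 2 to compound 3 (0.15 log units; within the scatter), perhaps within the scatter. Compound 3 is therefore estimated at 1600 nM, between 600 nM and 4500 nM.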

Compound 3, half-maximal inhibitory concentration: 3540 nM
For compound 3 the middle estimate is 2.2-fold (0.34 log units) below the measured one; low and high end bracket the measured number.
By their numbers in this assay, from the lowest: compounds 2, 3 and 1 (each within the scatter of the next, the first and the last beyond it).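

Adding phenyl in place of hydrogen on a saturated chain carbon bound to an aromatic carbon and an aromatic nitrogen gave a 1.6-fold higher number from compound 2 to compound 3 (0.20 log units; within the scatter) in this assay. This position therefore accepts a second phenyl with no step beyond the scatter, so the earlier gain seen with the first phenyl does not build further here. No available evidence accounts for this result.

The compounds shown leave open whether a longer chain bearing the phenyl would give a step beyond the scatter. They also leave open what an amine or a carboxylic acid on this carbon would do.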